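The source may report more compounds than this note shows. Statements on the series, on what has been measured and on what is new or still open speak of the compounds shown alone.

Three compounds share one core. Compound 1 `CCCCCCCCc1c(-c2ccccc2)sc(C(C)C)c1/C=C/[C@@H](O)C[C@@H](O)CC(=O)O` carries an octyl and a phenyl group. In an assay on microsomes for inhibition of 3-hydroxy-3-methylglutaryl-coenzyme A reductase (Rattus norvegicus) (a higher number here means a weaker inhibitor, a lower number a stronger inhibitor), compound 1 gives only a limit of the assay, > 10000 nM. Among the measured compounds shown here, compound 2 `CC(C)c1sc(-c2ccccc2)c(-c2ccc(F)cc2)c1/C=C/[C@@H](O)C[C@@H](O)CC(=O)O` in this assay gives 4.4 nM, the only true number among the three. Compound 3 `CC(C)c1sc(-c2ccccc2)c(-c2ccc(-c3ccccc3)cc2)c1/C=C/[C@@H](O)C[C@@H](O)CC(=O)O` in this assay also gives a limit, > 10000 nM. The measured steps were an at least 2200-fold lower number from compound 1 to compound 2 (3.35 log units; beyond the scatter) and an at least 2200-fold higher number from compound 2 to compound 3 (3.35 log units; beyond the scatter), both large, while a step that the two limits leave unreadable from compound 1 to compound 3. Compound 4 `CCCCCCCCc1sc(C(C)C)c(/C=C/[C@@H](O)C[C@@H](O)CC(=O)O)c1-c1ccc(F)cc1` differs from compound 2 by octyl in place of phenyl on an aromatic carbon. For the measured compounds named here, no measured step covers this exact change; the only compound carrying an octyl group, compound 1, sits at the limit of > 10000 nM in this assay, at which 2 of the 3 values shown sit. A weaker result is therefore expected for compound 4, with an estimate in this assay of 1500 nM, within 100 nM to 20000 nM. The expected step is a 340-fold higher number from compound 2 to compound 4 (2.53 log units; beyond the scatter).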

Compound 4, half-maximal inhibitory concentration: > 10000 nM
Compound 4: no number, only a limit; the forecaster's own chance of this, stated with the estimate: 40%; middle value at least 6.6-fold (0.82 log units) away from the limit.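

Octyl in place of phenyl next to the ring sulfur gives an at least 2200-fold higher number from compound 2 to compound 4 (3.35 log units; beyond the scatter) in this assay, so the octyl group is not accepted at this carbon either. The earlier compounds shown here had changed only the carbon bearing the 4-fluorophenyl group. Compound 4 gives only a limit of the assay, which leaves the true size of the loss unknown, and it joins the other compounds there: the limit of > 10000 nM in this assay, at which 3 of the 4 values shown sit.

From the compounds shown here alone, whether a methyl or an ethyl at this carbon keeps the low number of compound 2 remains open, and so does the effect of a pyridine ring in place of the phenyl.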